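This account rests on a few compounds, and the source may have more. Where it says the series, first, only, none or still open, it means among the compounds named here.

Compound 1 `Cc1cc(Br)ccc1NC(=O)COc1ccc2cc(/C=C3/SC(=O)NC3=O)ccc2c1`: 550 nM
Compound 2 `O=C(COc1ccc2cc(/C=C3/SC(=O)NC3=O)ccc2c1)Nc1cc(Cl)cc(C(F)(F)F)c1`: 4000 nM

In an assay on isolated protein for inhibition of histone deacetylase 4 (Homo sapiens), with a stated time of 1 h (on this read-out lower numbers stand for stronger inhibition and higher numbers for weaker inhibition), compound 1 gives 550 nM, and compound 2 gives 4000 nM. Going by the values given here, compound 2 thus stands at the higher of the two numbers measured so far, its only neighbour being compound 1, from which it is separated by a 7.3-fold higher number from compound 1 to compound 2 (0.86 log units; beyond the scatter). Compound 3 `O=C(COc1ccc2cc(/C=C3/SC(=O)NC3=O)ccc2c1)Nc1ccc(Br)c(Br)c1` has not been measured. It differs from compound 2 in a single place: 3,4-dibromophenyl in place of 3-chloro-5-(trifluoromethyl)phenyl on an amide-type nitrogen. Among the compounds with values here, only one measured step touches this position, a 7.3-fold higher number from compound 1 to compound 2 (0.86 log units; beyond the scatter), and it shows that exchanging the substituted phenyl on the amide-type nitrogen can move the read-out well beyond the scatter. That step, however, compares two substitution patterns that both differ from the one entering here, so it sets the scale of what a change at this position can do without fixing its direction for compound 3. A move back toward the region of compound 1 is taken as the more likely outcome. Compound 3 is therefore expected to come in at 1500 nM, within the range 400 nM to 6000 nM, which corresponds to an estimated 2.7-fold lower number from compound 2 to compound 3 (0.43 log units; beyond the scatter).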

Compound 3, half-maximal inhibitory concentration: 4900 nM
Beside the measured number, compound 3's estimate is 3.3-fold (0.51 log units) below it; the range from low to high includes it.
By their numbers in this assay, from the lowest: compound 1; then compounds 2 and 3 (each within the scatter of the next).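

In this assay, 3,4-dibromophenyl in place of 3-chloro-5-(trifluoromethyl)phenyl on the amide-type nitrogen gives a 1.2-fold higher number from compound 2 to compound 3 (0.09 log units; within the scatter) and so leaves the read-out unmoved, although the two groups differ in their halogens and in their heavy-atom count. The gap to compound 1 also recurs with this second group, as an 8.9-fold higher number from compound 1 to compound 3 (0.95 log units; beyond the scatter) shows, so it is not tied to the 3-chloro-5-(trifluoromethyl)phenyl group alone: of the three groups on this nitrogen, only 4-bromo-2-methylphenyl stands apart, and compound 1 is the most potent of the three compounds. Nothing in the available data explains this difference.

The compounds shown leave open whether the methyl or the bromine of the 4-bromo-2-methylphenyl group, or only the two together, sets compound 1 apart from compound 2 and compound 3. They also leave open how this assay would respond to a phenyl group on the same nitrogen carrying an amine or a carboxylic acid, or to a longer chain in place of the phenyl group.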